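This account rests on a few compounds, and the source may have more. Where it says the series, first, only, none or still open, it means among the compounds named here.

Three compounds share one core, joined through a three-carbon chain to an amine. In a physicochemical assay for acid dissociation, compound 1 `COc1ccc(F)cc1CNCCCNc1ccnc2cc(CCC(C)C)ccc12` gives 9.47, and compound 3 `COc1ccc(F)cc1CNCCCNc1ccnc2cc(-c3ccccc3)ccc12` gives 9.47. Compound 2 `COc1cccc(Oc2ccc3c(NCCCNCc4cc(F)ccc4OC)ccnc3c2)c1` gives 9.28, the lowest of the three numbers, yet the steps of a number 0.19 log units lower from compound 1 to compound 2 (within the scatter) and a number 0.19 log units higher from compound 2 to compound 3 (within the scatter) both lie within the scatter, so the three values sit together. Compound 4 `COc1cccc(Oc2ccc3c(NCCCNCc4ccco4)ccnc3c2)c1` is compound 2 with furan-2-yl in place of 5-fluoro-2-methoxyphenyl on a saturated chain carbon bound to an amine nitrogen. Among the compounds with values here, every measured step swaps a group on an aromatic carbon of the core; none touches the saturated chain carbon bound to the amine nitrogen, so no measured step bears directly on this change. Only a small shift, a number 0.18 log units lower from compound 2 to compound 4 (within the scatter), is expected. Compound 4 is expected to give 9.1, somewhere between 8.5 and 9.7.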

Compound 4, acid dissociation constant: 9.28
Compound 4: middle estimate off by 0.18 log units, on the low side; the range from low to high includes it.
By their numbers in this assay, from the lowest: compounds 2, 4, 1 and 3 (each within the scatter of the next).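

In this assay, within the data shown here, the first measured change on a saturated chain carbon bound to an amine nitrogen shows no change at the digits printed from compound 2 to compound 4 (within the scatter) and so leaves the read-out level. Here furan-2-yl, a five-membered aromatic ring, takes the place of 5-fluoro-2-methoxyphenyl, a larger six-membered one. No measurement shown here explains this result.

Going by these compounds, it remains open whether a non-aromatic group at this place, such as a cyclohexyl ring or a longer alkyl chain, would give a similar number. Furan-2-yl also appears here only with 3-methoxyphenoxy on the core, so its pairing with phenyl or isopentyl remains open.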